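The source may hold more compounds than are shown below. What is called first, only, known or untested is meant among the compounds shown, and "the series" means these compounds.

Compound 1 `COc1ccc(C2=C(c3cc(OC)c(OC)c(OC)c3)C(=O)C(O)C2)cc1`: > 100 ug/mL, a limit
Compound 2 `COc1ccc(C2=C(c3cc(OC)c(OC)c(OC)c3)C(=O)C(O)C2)cc1Cl`: 40 ug/mL

Both compounds were tested in an ADME assay on DU-145 cells (Homo sapiens) for cytotoxicity, read by MTT assay, with a stated time of 72 h; a lower number here means a stronger inhibitor, a higher number a weaker inhibitor. Within the data shown here, compound 2 holds the only exact number so far, 40 ug/mL. Compound 1 stands at a limit: the limit of > 100 ug/mL in this assay, at which 1 of the 2 values shown sits.

Compound 3 `COc1ccc(C2=C(c3cc(OC)c(OC)c(OC)c3)C(=O)C(O)C2)cc1F` alters compound 2 in one place: fluoro in place of chloro on an aromatic carbon. In words, this is fluoro in place of chloro on an aromatic carbon, the change from 3-chloro-4-methoxyphenyl to 3-fluoro-4-methoxyphenyl.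

Among the measured compounds shown here, only one measured step bears on this carbon: an at least 2.5-fold lower number from compound 1 to compound 2 (0.39 log units; beyond the scatter). Chloro replacing hydrogen there gave a lower number, so chloro clearly counts for something, though the true size of that step stays open. For the measured compounds named here, no fluoro compound has been measured yet. A reasonable guess is that fluoro keeps part of the gain seen in that step from compound 1 to compound 2, not all of it. The expected change is a small move toward a weaker compound, not clearly beyond the usual scatter: a 1.8-fold higher number from compound 2 to compound 3 (0.24 log units; within the scatter). For compound 3 the estimated value is 70 ug/mL, with an expected range from 30 ug/mL to 160 ug/mL.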

Compound 3, half-maximal inhibitory concentration: 27 ug/mL
For compound 3 the middle estimate is 2.6-fold (0.41 log units) above the measured one; the whole stated range lies above it.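

In this assay, putting fluoro in place of chloro on this aromatic carbon gives a 1.5-fold lower number from compound 2 to compound 3 (0.17 log units; within the scatter), so the two groups cannot be told apart here. Fluoro in place of hydrogen gives an at least 3.7-fold lower number from compound 1 to compound 3 (0.56 log units; beyond the scatter), which means that the step away from hydrogen seen with chloro is now also seen with a second, different atom at the same carbon. The true size of the steps from hydrogen stays open because compound 1 sits at a limit, so each can be read only as a minimum: the limit of > 100 ug/mL in this assay, at which 1 of the 3 values shown sits.

The compounds shown leave open whether a group of another kind at this carbon, such as a methyl, an amine or a carboxylic acid, would give a number close to those of chloro and fluoro or move it further in either direction. They also leave open whether the same replacements would have a similar effect elsewhere on the 4-methoxyphenyl ring, since all three compounds differ only at the carbon ortho to the methoxy group.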